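Saturated amine swap on the chain carbon of compound 3

The source may report more compounds than this note shows. Statements on the series, on what has been measured and on what is new or still open speak of the compounds shown alone.

The measured compounds and their results in an ADME assay on Vero cells (Chlorocebus sabaeus) for cytotoxicity, with a stated time of 7 days; a lower number here means that less compound is tolerated, a higher number that more compound is tolerated:
compound 1 `COc1ccc2[nH]c(C(=O)N3CC(=O)N(Cc4ccccc4)[C@@H](COCc4ccccc4)C3)cc2c1`: in this assay compound 1 gives > 30000 nM, which is a limit of the assay and not a number.
compound 2 `COc1ccc2[nH]c(C(=O)N3CC(=O)N(Cc4ccccc4)[C@@H](CN4CCN(c5ccccn5)CC4)C3)cc2c1`: in this assay compound 2 gives > 30000 nM, again a limit of the assay.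
compound 3 `COc1ccc2[nH]c(C(=O)N3CC(=O)N(Cc4ccccc4)[C@@H](CN4CC5CCCCC5C4)C3)cc2c1`: in this assay compound 3 gives 8200 nM.

Going by the values given here, compound 3 therefore holds the only actual number among the three; the other two sit at the limit of > 30000 nM in this assay, at which 2 of the 3 values shown sit. Compound 4 `COc1ccc2[nH]c(C(=O)N3CC(=O)N(Cc4ccccc4)[C@@H](CN4CCC5(CCCC5)CC4)C3)cc2c1` differs from compound 3 in that (a group of 10 heavy atoms (9 carbon, 1 nitrogen; one five-membered non-aromatic ring of carbon only, one six-membered non-aromatic ring with 1 hetero atom) in place of a group of 9 heavy atoms (8 carbon, 1 nitrogen; one five-membered non-aromatic ring with 1 hetero atom, one six-membered non-aromatic ring of carbon only), on a saturated chain carbon bound to a saturated ring carbon). Two measured steps lead into compound 3: an at least 3.6-fold lower number from compound 1 to compound 3 (0.56 log units; beyond the scatter) and an at least 3.6-fold lower number from compound 2 to compound 3 (0.56 log units; beyond the scatter). Both steps replace a group bearing an aromatic ring with a saturated bicyclic amine, while compound 4 exchanges one saturated bicyclic amine for another of nearly the same size. Among the compounds with values here, no measured step shows that this kind of swap shifts this assay. The step of a 1.2-fold higher number from compound 3 to compound 4 (0.09 log units; within the scatter) is therefore expected to stay within the scatter. Compound 4 is estimated at 10000 nM, within 4000 nM to 30000 nM.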

Compound 4, half-maximal cytotoxic concentration: 3600 nM
Compound 4: the middle estimate sits 2.8-fold (0.44 log units) above what was measured; measured number outside the range, below it.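

In this assay, going by these compounds alone, exchanging one saturated bicyclic amine for another on the saturated chain carbon still moves the read-out, with a 2.3-fold lower number from compound 3 to compound 4 (0.36 log units; beyond the scatter), so this position responds even when no aromatic ring is involved in the swap, which the earlier steps could not show. Set against the groups bearing an aromatic ring, the new amine gives an at least 8.3-fold lower number from compound 2 to compound 4 (0.92 log units; beyond the scatter) and an at least 8.3-fold lower number from compound 1 to compound 4 (0.92 log units; beyond the scatter). Compound 1 and compound 2 each stand at a limit of the assay and not at a number: the limit of > 30000 nM in this assay, at which 2 of the 4 values shown sit.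

With only two actual numbers, the compounds shown cannot separate the size of the amine from the arrangement of its rings. Going by these compounds, what a morpholine, a simple piperidine or an open-chain diethylamine would give on this chain carbon stays open.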